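The source may hold more compounds than are shown below. What is called first, only, known or untested is meant among the compounds shown, and "the series" means these compounds.

Compound 1 `COc1cc(-c2cc(/C=C/C(=O)c3ccc(N)cc3)[nH]n2)cc(OC)c1OC` and compound 2 `COc1ccc(-c2cc(/C=C/C(=O)c3ccc(N)cc3)[nH]n2)cc1OC` share one core. In a functional assay on CCRF-CEM cells (Homo sapiens) for inhibition, read by sulforhodamine B assay, with a stated time of 48 h (a higher number here means that more compound is tolerated, a lower number that less compound is tolerated), compound 1 gives a limit, > 100000 nM, not a number. In this assay compound 2 also gives a limit, > 100000 nM. The change between the two is hydrogen in place of methoxy on an aromatic carbon, and the step that the two limits leave unreadable from compound 1 to compound 2 cannot be sized from two limits. Compound 3 `COc1cc(C(=O)/C=C/c2cc(-c3cc(OC)c(OC)c(OC)c3)n[nH]2)cc(OC)c1OC` is built on another core; the difference between the two cores is not broken down here. In this assay compound 3 gives a limit as well, > 100000 nM. Compound 4 `COc1ccc(-c2cc(/C=C/C(=O)c3cc(OC)c(OC)c(OC)c3)[nH]n2)cc1OC` arises from compound 3 by the same change, (hydrogen in place of methoxy on an aromatic carbon). Because (the limit of > 100000 nM in this assay, at which 3 of the 3 values shown sit), the step expected here is a step that the limit leaves unreadable from compound 3 to compound 4, to be set beside the unreadable earlier one. Compound 4 is thus expected to give about 150000 nM, between 50000 nM and 500000 nM, most probably again as a limit.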

Compound 4, concentration lethal to 50% of the cells: > 100000 nM
Compound 4 ended at the assay's limit; the forecaster's own chance of this, stated with the estimate: 85%; the middle value is on the limit's open side.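

No step can be read from compound 3 to compound 4, since each result is a limit and not a number: the limit of > 100000 nM in this assay, at which 4 of the 4 values shown sit. In this assay the compounds shown leave open whether hydrogen in place of methoxy changes anything at all.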